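This account rests on a few compounds, and the source may have more. Where it says the series, first, only, none or still open, it means among the compounds named here.

Compounds measured so far:
- compound 1, `CCNc1nc(C)c(-c2nc3ccccc3s2)c(N[C@@H]2C[C@H](CO)[C@@H](O)[C@H]2O)n1`: 2580 ng.h/mL
- compound 2, `COCCNc1nc(C)c(-c2nc3ccccc3s2)c(N[C@@H]2C[C@H](CO)[C@@H](O)[C@H]2O)n1`: 2630 ng.h/mL
- compound 3, `Cc1nc(NCCC(F)(F)F)nc(N[C@@H]2C[C@H](CO)[C@@H](O)[C@H]2O)c1-c1nc2ccccc2s1`: 2560 ng.h/mL

These three compounds share one core and differ only in the group carried on the saturated chain attached to a nitrogen on an aromatic ring. In an ADME assay on the whole organism (plasma) for pharmacokinetics, with Rattus norvegicus as the target, with a stated time of 6 h, at a dose of 10 mg/kg by the oral route (a higher number here means more compound in the circulation at the dose given, a lower number less compound in the circulation), compound 2 gives the highest of the three numbers, but its lead is nominal: the step of a 1.0-fold higher number from compound 1 to compound 2 (0.01 log units; within the scatter) and the step of a 1.0-fold lower number from compound 2 to compound 3 (0.01 log units; within the scatter) are both within the scatter, as is a 1.0-fold lower number from compound 1 to compound 3 (0.00 log units; within the scatter). On these numbers the three compounds cannot be told apart.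

Compound 4, `Cc1nc(NCc2cccnc2)nc(N[C@@H]2C[C@H](CO)[C@@H](O)[C@H]2O)c1-c1nc2ccccc2s1`, has not yet been measured in this assay. Relative to compound 2 it carries pyridin-3-yl in place of methoxymethyl on a saturated chain carbon bound to a nitrogen on an aromatic ring. This change is larger than any of the three measured steps, which all exchanged one small group on the chain for another, so they bear on it only loosely. Every change tried so far left the number essentially where it was, and no step beyond the scatter is expected here either, so compound 4 is estimated at 2200 ng.h/mL, with a range from 900 ng.h/mL to 5000 ng.h/mL, meaning an expected step of a 1.2-fold lower number from compound 2 to compound 4 (0.08 log units; within the scatter).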

Compound 4, area under the concentration-time curve: 9.57 ng.h/mL
Compound 4: middle estimate off by 230-fold (2.36 log units), on the high side; measured number outside the range, below it.
By their numbers in this assay, from the lowest: compound 4; then compounds 3, 1 and 2 (each within the scatter of the next).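

In this assay the place on a saturated chain carbon bound to a nitrogen on an aromatic ring turns out not to be indifferent to what it carries: going from 2-methoxyethyl to (pyridin-3-yl)methyl gives a 270-fold lower number from compound 2 to compound 4 (2.44 log units; beyond the scatter) and the other two chains give the same picture, with a 270-fold lower number from compound 3 to compound 4 (2.43 log units; beyond the scatter) and a 270-fold lower number from compound 1 to compound 4 (2.43 log units; beyond the scatter). Going by these compounds alone, the flat result of the earlier exchanges therefore holds only for the three open chains, and compound 4 is the one compound here with a ring on this chain. Nothing measured here accounts for the loss, so its origin stays unassigned.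

As far as these compounds go, it remains open whether the ring as such, its nitrogen or the length of the link goes with the low number. A benzyl group or a 2-(pyridin-3-yl)ethyl chain in this place would bear on that question.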